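Amide substituent change in a two-compound series, compound 3 outlook

The compounds below may be only part of what the source reports. "The series", "measured", "known", "first", "only" and "open" are said of these compounds alone.

Of the compounds shown here, two have numbers so far. Compound 1 `O=C(NC1CCCC1)c1cc2ccccc2oc1=O` was run in an assay on HeLa cells for displacement of a labelled ligand from adenosine receptor A3 (Homo sapiens), read by scintillation counting, with a stated time of 180 min, tested at 10 uM (a higher number here means more inhibition at the concentration tested (going by the name of the read-out), a lower number less inhibition), and gives 20%. Compound 2 `CCC(CO)NC(=O)c1cc2cc(Br)ccc2oc1=N` differs from compound 1 in more than one place; in this assay compound 2 gives 24%. The two values lie within the usual scatter of each other, so neither compound can be set apart from the other on this read-out; compound 1 holds the lower of the two numbers, but by a margin the scatter covers. Within the data shown here, no pair of measured compounds differs in a single place, so no measured step is available as a guide.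

Compound 3 `O=C(O)CNC(=O)c1cc2ccccc2oc1=O` is not yet measured. It departs from compound 1 as follows: carboxymethyl in place of cyclopentyl on an amide-type nitrogen. Among the measured compounds shown here, no measured step of this kind exists, so the expectation rests on the structural change alone. The step expected here, a number 10 percentage points lower from compound 1 to compound 3 (within the scatter), runs downward and is of a size at or a little beyond the usual scatter. Compound 3 is estimated at 10% in this assay, with a range from -5% to 25%.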

Compound 3, a percentage reported as inhibition, at one concentration (the size of the read-out at that concentration, not a potency): 0%
Compound 3: middle estimate off by 10 percentage points, on the high side; the range from low to high includes it.
By their numbers in this assay, from the lowest: compound 3; then compounds 1 and 2 (each within the scatter of the next).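

Carboxymethyl in place of cyclopentyl on an amide-type nitrogen gives, in this assay, a number 20 percentage points lower from compound 1 to compound 3 (beyond the scatter), the only step in the series that changes a single place. Among these compounds, compound 1 and compound 2 differ in more than one place and stay within the scatter of each other, so only this pair shows that the group on this nitrogen can move the read-out on its own. Nothing on hand bears on why the number falls, so the step stands as an observation on one pair.

The compounds shown leave open whether the step follows from the carboxylic acid entering or from the cyclopentyl ring leaving; a plain ethyl group, a cyclohexyl ring or the methyl ester of the same chain on this nitrogen would separate the two. Also open, as far as these compounds go, is whether a longer chain ending in a carboxylic acid, or one ending in an amine, behaves like carboxymethyl, and whether the same change on the core of compound 2 gives a step of like size.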